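This account rests on a few compounds, and the source may have more. Where it says the series, first, only, none or still open, it means among the compounds named here.

In a functional assay on HCT-116 cells (Homo sapiens) for antiproliferative activity, read by MTT assay, with a stated time of 72 h (on this read-out higher numbers stand for weaker inhibition and lower numbers for stronger inhibition), compound 3 (`COc1ccc(/C=C/C(=O)/C=C(O)/C=C/c2ccc(OC)c(OC(=O)C(C)(CO)CO)c2)cc1OC(=O)C(C)(CO)CO`) gives 2790 nM. This value lies within the usual scatter of compound 2 (`CC(CO)(CO)C(=O)Oc1ccc(/C=C/C(=O)/C=C(O)/C=C/c2ccc(OC(=O)C(C)(CO)CO)cc2)cc1`), which gives 4100 nM, so the data do not separate the two. Compound 1 (`COc1cc(/C=C/C(O)=C/C(=O)/C=C/c2ccc(OC(=O)C(C)(CO)CO)c(OC)c2)ccc1O`) gives 15500 nM, a higher number that stands beyond the scatter from compound 3 and so means weaker inhibition.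

Compound 4 (`COc1ccc(/C=C/C(O)=C/C(=O)/C=C/c2ccc(OC)c(OC(=O)C(C)(CO)CO)c2)cc1O`) comes from compound 3 through a single change: hydrogen in place of (1,1-bis(hydroxymethyl)ethyl)carbonyl on an oxygen on an aromatic ring. Hydrogen takes the place of (1,1-bis(hydroxymethyl)ethyl)carbonyl on an oxygen on an aromatic ring, which turns ((1,1-bis(hydroxymethyl)ethyl)carbonyl)oxy into hydroxy.

Within the data shown here, no pair of measured compounds differs in one place only, so this change has no direct precedent in the data. The nearest guide is compound 1, which also carries a hydroxy on an aromatic ring and gives 15500 nM, while compound 2 and compound 3 carry none. Compound 1 differs from compound 3 in other ways too, so this guide is loose.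

In this assay, a moderate move toward a higher number, beyond the scatter, is therefore expected. The expected size is a 3.2-fold higher number from compound 3 to compound 4 (0.51 log units; beyond the scatter). The estimate for compound 4 is 9000 nM, with an expected range from 3500 nM to 20000 nM.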

Compound 4, half-maximal inhibitory concentration: 1950 nM
For compound 4 the middle estimate is 4.6-fold (0.66 log units) above the measured one; the whole stated range lies above it.
By their numbers in this assay, from the lowest: compounds 4, 3 and 2 (each within the scatter of the next, the first and the last beyond it); then compound 1.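

Among these compounds, replacing (1,1-bis(hydroxymethyl)ethyl)carbonyl with hydrogen on an oxygen on an aromatic ring gives a 1.4-fold lower number from compound 3 to compound 4 (0.16 log units; within the scatter) in this assay, the first step in this set between compounds that differ in one place. At this position, then, the assay does not separate the ((1,1-bis(hydroxymethyl)ethyl)carbonyl)oxy group from a hydroxy, even though the change removes the whole ester side chain, and the hydroxy carried by compound 1 proves no guide to what a hydroxy does here. Nothing available accounts for this result, and the data give no reason why the two groups read alike.

The compounds shown leave open whether any other group on this oxygen, such as a methyl ether, an acetyl ester or an ester with a longer chain bearing an amine or a carboxylic acid, would also stay within the scatter of compound 4. They also leave open whether the same replacement at the ester that remains in compound 4 would read the same way, since a single step at one position cannot tell how the two ester sites compare.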